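The source may hold more compounds than are shown below. What is called first, only, known or untested is meant among the compounds shown, and "the series" means these compounds.

Measured so far:
- compound 1, `NC(N)=NC(=O)c1nc(Cl)c(NCc2cccc(F)c2)nc1N`, giving 29%
- compound 2, `NC(N)=NC(=O)c1nc(Cl)c(N2CCCCC2)nc1N`, giving "not determined" (no result reported)

Two compounds share a core and differ only in the group attached to one carbon of that core. In an assay for inhibition of acid-sensing ion channel 3 (Homo sapiens), read by patch clamp, tested at 1 uM (on this read-out higher numbers stand for more inhibition at the one concentration tested (going by the name of the read-out) and lower numbers for less inhibition), compound 1 gives 29%, a modest degree of block at the single concentration tested. Among the measured compounds shown here, for compound 2 this assay reports "not determined" (no result reported), so there is no number to place it against compound 1, and no step between two measured compounds can be worked out here.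

The next compound, compound 3, `NC(N)=NC(=O)c1nc(Cl)c(Sc2ccccc2)nc1N`, is reached from compound 2 by one change: phenylsulfanyl in place of piperidin-1-yl on an aromatic carbon. The group that leaves is a saturated ring joined through nitrogen; the group that enters is a flat aromatic ring joined through sulfur.

For the measured compounds named here, without a value for compound 2, the only anchor is compound 1 with 29%. The expectation is that compound 3 lands somewhere near that level, with a wide range because nothing else is known. Compound 3 is estimated to give 30% in this assay, between 5% and 60%.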

Compound 3, a percentage reported as inhibition, at one concentration (the size of the read-out at that concentration, not a potency): 11%
Beside the measured number, compound 3's estimate is 19 percentage points above it, and the stated range covers the measured number.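

Among the compounds shown here, compound 2 carries no number in this assay, so no step from it to compound 3 can be read. Going by these compounds, whether phenylsulfanyl gives more or less inhibition than piperidin-1-yl at this position on the shared core stays open, and no supporting data bear on the result for compound 3.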